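Two Chromone Analogues and a Dichlorophenyl Variant

The source may report more compounds than this note shows. Statements on the series, on what has been measured and on what is new or still open speak of the compounds shown alone.

Compounds measured so far:
compound 1 `Cc1cc(=O)c2c(O)c(CN3CCN(C(=O)OC(C)(C)C)CC3)c(O)c([C@H]3CCN(C)C[C@H]3O)c2o1`: 1%
compound 2 `Cc1oc2c([C@H]3CCN(C)C[C@H]3O)c(O)cc(O)c2c(=O)c1C(O)c1ccc(Cl)cc1`: 41%

The read-out is a functional assay on PC-3 cells (Homo sapiens) for inhibition, read by MTT assay, with a stated time of 48 h, tested at 10 uM; a higher number here means more inhibition of growth at the concentration tested, a lower number less inhibition of growth. In this assay compound 1 gives 1%, a number close to no inhibition. Compound 2 gives 41%, the higher of the two numbers shown, and the gap to compound 1 lies beyond the usual scatter of this kind of measurement. Compounds 1 and 2 differ in more than one place, so their two values are reported side by side without a counted step between them.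

Compound 3 `Cc1oc2c([C@H]3CCN(C)C[C@H]3O)c(O)cc(O)c2c(=O)c1C(O)c1cccc(Cl)c1Cl` has not yet been measured. It differs from compound 2 in one place only: 2,3-dichlorophenyl in place of 4-chlorophenyl on a saturated chain carbon bound to an aromatic carbon and an oxygen on a saturated carbon. Going by the values given here, no measured pair in this set shows such a change, so its effect is unknown from the data. Among the compounds with values here, with only two measured compounds and no comparable step to lean on, the step from compound 2 to compound 3 is expected to be small, and the estimated change is a number 4 percentage points higher from compound 2 to compound 3 (within the scatter), which could fall within the scatter in either direction. Compound 3 is therefore expected to give about 45%, with a range from 20% to 70%.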

Compound 3, percent growth inhibition at one concentration: 20%
Beside the measured number, compound 3's estimate is 25 percentage points above it; measured number inside the range.
By their numbers in this assay, from the lowest: compound 1; then compound 3; then compound 2.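

In this assay, putting 2,3-dichlorophenyl in place of 4-chlorophenyl, on a saturated chain carbon bound to an aromatic carbon and an oxygen on a saturated carbon, gives a number 21 percentage points lower from compound 2 to compound 3 (beyond the scatter). Going by these compounds alone, this is the first comparison in the set in which only one part of the molecule changes, and it shows that the aromatic group at this place is not a silent passenger: with the rest of the structure held constant, changing that ring alone shifts growth inhibition at the concentration tested, and here the compound carrying the extra chlorine has the lower number. No measurement at hand gives a reason for this drop.

This single step changes both the number of chlorines on the ring and where they sit, so the compounds shown cannot separate the two effects. Also open, on these data alone, is where the number would land with a plain phenyl, a methoxyphenyl or an aminophenyl at this place, each of which would show whether any chlorine on this ring matters for growth inhibition.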